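A few compounds are considered here, and "the series" means these few. Any claim that something is new, unique, unknown or untested is made for them only; others in the source may bear on it.

Working notes on the series. Compound 1 `COc1c(N2CCN(c3nnc(-c4ccc([N+](=O)[O-])o4)s3)C(C)C2)c(F)cc2c(=O)c(C(=O)O)cn(C3CC3)c12` and compound 2 `COc1c(N2CCN(c3nnc(-c4ccccc4[N+](=O)[O-])s3)C(C)C2)c(F)cc2c(=O)c(C(=O)O)cn(C3CC3)c12` have been measured in an ADME assay on NIH3T3 cells (Mus musculus) for cytotoxicity, read by MTT assay, with a stated time of 72 h; a higher number here means a weaker inhibitor, a lower number a stronger inhibitor: compound 1 gives 238000 nM and compound 2 gives 168000 nM, so compound 2 holds the lower of the two numbers, though the step of a 1.4-fold lower number from compound 1 to compound 2 (0.15 log units; within the scatter) stays within the scatter. Compound 3 `COc1c(N2CCN(c3nnc(-c4ccc([N+](=O)[O-])cc4)s3)C(C)C2)c(F)cc2c(=O)c(C(=O)O)cn(C3CC3)c12` differs from compound 2 by 4-nitrophenyl in place of 2-nitrophenyl on an aromatic carbon. Going by the values given here, no measured step probes a moved nitro group on the same phenyl ring; the only step known, a 1.4-fold lower number from compound 1 to compound 2 (0.15 log units; within the scatter), swapped the whole aromatic unit without a clear effect. For compound 3 no step beyond the scatter is therefore expected in this assay, an expected 1.0-fold higher number from compound 2 to compound 3 (0.01 log units; within the scatter). Compound 3 is estimated at 170000 nM, range 70000 nM to 400000 nM.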

Compound 3, half-maximal inhibitory concentration: 223000 nM
Compound 3: the middle estimate sits 1.3-fold (0.12 log units) below what was measured; measured number inside the range.
By their numbers in this assay, from the lowest: compounds 2, 3 and 1 (each within the scatter of the next).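

Going by these compounds alone, exchanging 2-nitrophenyl for 4-nitrophenyl on the same aromatic carbon in this assay gives a 1.3-fold higher number from compound 2 to compound 3 (0.12 log units; within the scatter), the first reading of where the nitro group sits on the phenyl ring. Exchanging 5-nitrofuran-2-yl for 4-nitrophenyl gives a 1.1-fold lower number from compound 1 to compound 3 (0.03 log units; within the scatter), so at this place neither the nitro position nor the aromatic unit separates the three compounds. Nothing available bears on the reason for this flat reading.

From the compounds shown here alone, all three compounds carry a nitro group, so it remains open whether an amine or a carboxylic acid in its place would shift the number beyond the scatter.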